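The source may report more compounds than this note shows. Statements on the series, on what has been measured and on what is new or still open speak of the compounds shown alone.

Compound 3 `COc1cc2c(Oc3ccc(NC(=O)c4cn(-c5ccccc5)nn4)cc3F)ccnc2cc1OCCCN1CCN(C)CC1` bears a 4-methylpiperazin-1-yl group on the chain; in a functional assay on NCI-H460 cells (Homo sapiens) for cytotoxicity, read by MTT assay, with a stated time of 72 h (a lower number here means a stronger inhibitor, a higher number a weaker inhibitor), compound 3 gives 200 nM. Its two companions share the same core and differ only in that amine group: compound 1 `COc1cc2c(Oc3ccc(NC(=O)c4cn(-c5ccccc5)nn4)cc3F)ccnc2cc1OCCCN1CCCC1` gives 280 nM in this assay, and compound 2 `COc1cc2c(Oc3ccc(NC(=O)c4cn(-c5ccccc5)nn4)cc3F)ccnc2cc1OCCCN1CCCCC1` gives 210 nM. The steps among them are small: a 1.3-fold lower number from compound 1 to compound 2 (0.12 log units; within the scatter), a 1.4-fold lower number from compound 1 to compound 3 (0.15 log units; within the scatter) and a 1.1-fold lower number from compound 2 to compound 3 (0.02 log units; within the scatter). Compound 3 thus stands at the lowest of the three numbers, yet within the scatter of both of the others, so no order among them can be claimed.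

Compound 4 `COc1cc2c(Oc3ccc(NC(=O)c4cn(-c5ccc(F)c(F)c5)nn4)cc3F)ccnc2cc1OCCCN1CCN(C)CC1` keeps the amine group of compound 3 and is changed elsewhere: 3,4-difluorophenyl in place of phenyl on an aromatic nitrogen. None of the three measured steps touches this aromatic ring; each concerns only the amine three bonds along the chain from an oxygen on an aromatic ring, and each stayed within the scatter. For the measured compounds named here, no measured step therefore bears on the change from compound 3 to compound 4, and the expectation can rest only on the shared remainder of the structure. Compound 4 is expected to give 220 nM in this assay, with a range from 90 nM to 550 nM. The step this implies, a 1.1-fold higher number from compound 3 to compound 4 (0.04 log units; within the scatter), is expected to remain within the scatter.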

Compound 4, half-maximal inhibitory concentration: 250 nM
The estimate for compound 4 lay 1.1-fold (0.06 log units) below the measured number; low and high end bracket the measured number.
By their numbers in this assay, from the lowest: compounds 3, 2, 4 and 1 (each within the scatter of the next).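

For the compounds shown here, the three earlier compounds varied only the amine on the chain, so compound 4 gives the first reading of the other end of the molecule, the group on an aromatic nitrogen of a five-membered aromatic ring with 3 nitrogen. In this assay, 3,4-difluorophenyl in place of phenyl gives a 1.3-fold higher number from compound 3 to compound 4 (0.10 log units; within the scatter), so compound 3 and compound 4 cannot be told apart, and this one change at this position stays as small as the steps among the amines. Nothing measured here speaks to a cause for this result.

Going by these compounds, this reading holds only with the 4-methylpiperazin-1-yl amine on the chain, so it remains open whether 3,4-difluorophenyl would behave alike with the pyrrolidin-1-yl amine of compound 1 or the piperidin-1-yl amine of compound 2. It also remains open whether a quite different group on that aromatic nitrogen, such as 4-methoxyphenyl, a pyridin-3-yl ring, benzyl or cyclohexyl, would give a step beyond the scatter, since phenyl and 3,4-difluorophenyl are the only two groups shown there.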